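Dimethoxy on the anilino ring of the sulfonyl quinoxaline series

This account rests on a few compounds, and the source may have more. Where it says the series, first, only, none or still open, it means among the compounds named here.

Compound 3 `Cc1ccc(S(=O)(=O)c2nc3ccccc3nc2Nc2ccccc2)cc1` gives 400 nM in a functional assay on HL-60 cells (Homo sapiens) for cytotoxicity, read by MTT assay, with a stated time of 72 h (on this read-out lower numbers stand for stronger inhibition and higher numbers for weaker inhibition), the second highest of the three numbers. Nearest stands compound 1 `O=S(=O)(c1ccccc1)c1nc2ccccc2nc1Nc1ccccc1` at 140 nM, reached by a 2.9-fold higher number from compound 1 to compound 3 (0.46 log units; beyond the scatter); furthest stands compound 2 `COc1cc(Nc2nc3ccccc3nc2S(=O)(=O)c2ccccc2)cc(OC)c1OC` at 1770 nM. Compound 4 `COc1cc(Nc2nc3ccccc3nc2S(=O)(=O)c2ccc(C)cc2)cc(OC)c1` differs from compound 3 by 3,5-dimethoxyphenyl in place of phenyl on a nitrogen on an aromatic ring. Among the compounds with values here, no measured step covers this change alone; the closest comparison is compound 1 against compound 2, where the trimethoxy anilino ring carries the higher number by a wide margin. On that basis a higher number is expected for compound 4, by roughly a 5.0-fold higher number from compound 3 to compound 4 (0.70 log units; beyond the scatter), with uncertainty because only compound 2 1770 nM informs it. Compound 4 is therefore estimated at 2000 nM, range 700 nM to 6000 nM.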

Compound 4, half-maximal inhibitory concentration: 20 nM
Compound 4: the middle estimate sits 100-fold (2.00 log units) above what was measured; the measured number lies below the stated range.
By their numbers in this assay, from the lowest: compound 4; then compound 1; then compound 3; then compound 2.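

The step of a 20-fold lower number from compound 3 to compound 4 (1.30 log units; beyond the scatter) in this assay shows that 3,5-dimethoxyphenyl on a nitrogen on an aromatic ring can give a large gain. Compound 1 at 140 nM and compound 2 at 1770 nM therefore do not describe methoxy groups on this ring in general, and the pattern of groups matters within these compounds. No measurement shown gives a reason for this step.

Open, going by these compounds, is whether a single methoxy, an amine or a carboxylic acid on this ring would follow compound 4 or compound 2.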